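Swapping the furan for a dimethylaminophenyl on an amide chain

The source may hold more compounds than are shown below. What is called first, only, known or untested is meant among the compounds shown, and "the series" means these compounds.

The measured compounds:
compound 1 `N[C@H]1CC[C@H](Nc2c(C(=O)NCc3ccco3)nc(Br)c3cccnc23)CC1`: "not determined" (no result reported)
compound 2 `O=C(NCc1ccc(F)cc1)c1nc(NCCO)c2cccnc2c1O`: "not determined" (no result reported)
compound 3 `CNCCCNc1c(C(=O)NCc2ccc(F)cc2)nc(Br)c2cccnc12`: > 10000 nM

Compound 1 has no number of its own in a functional assay on MCF7 cells (Homo sapiens) for cytotoxicity, read by MTT assay, with a stated time of 72 h; on this read-out lower numbers stand for stronger inhibition and higher numbers for weaker inhibition; in this assay compound 1 is "not determined" (no result reported), and compound 2 is likewise "not determined" (no result reported). Compound 3 gives only a limit of the assay, > 10000 nM, as shown by the limit of > 10000 nM in this assay, at which 1 of the 3 values shown sits. So compound 1 stands nowhere on a scale: of three entries, one is a limit and the other two carry no result.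

Compound 4 `CN(C)c1ccc(CNC(=O)c2nc(Br)c3cccnc3c2N[C@H]2CC[C@H](N)CC2)cc1` differs from compound 1 by 4-(dimethylamino)phenyl in place of furan-2-yl on a saturated chain carbon bound to an amide-type nitrogen. Among the measured compounds shown here, with no measured step to guide the size or direction of the change, and one inactive relative, compound 4 is expected to sit near 5000 nM, somewhere between 500 nM and 50000 nM.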

Compound 4, half-maximal inhibitory concentration: 5000 nM
Compound 4: middle estimate and measured number agree at the digits printed, and the stated range covers the measured number.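

Among the compounds shown here, compound 1 has no number of its own in this assay, so no step from it to compound 4 can be read. On these data alone, whether 4-(dimethylamino)phenyl in place of furan-2-yl changes cytotoxicity, and in which direction, stays open.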